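The source may report more compounds than this note shows. Statements on the series, on what has been measured and on what is new or still open speak of the compounds shown alone.

Measured so far in a functional assay on MCF7 cells (Homo sapiens) for inhibition, read by fluorescence, with a stated time of 72 h; on this read-out lower numbers stand for stronger inhibition and higher numbers for weaker inhibition:
- compound 1 `CC(C)[C@@H](N)COc1nc(NC(=N)N)c2ncn(C(C)C)c2n1`: 79400 nM
- compound 2 `CC(C)n1cnc2c(NC(=N)N)nc(NC3CC3)nc21`: 5400 nM

Not yet measured:
- compound 3 `CC(C)n1cnc2c(NC(=N)N)nc(OC[C@@H]3CCCN3)nc21`

Compound 2 holds the lower of the two numbers, 5400 nM. The next change is (pyrrolidin-2-yl)methoxy in place of cyclopropylamino on an aromatic carbon. Within the data shown here, only one measured step bears on it, the large 15-fold lower number from compound 1 to compound 2 (1.17 log units; beyond the scatter), in which cyclopropylamino replaced 2-amino-3-methylbutoxy. Compound 3 gives up that same cyclopropylamino, so a sizeable part of this step is expected to reverse in this assay, towards a higher number, although a single step is thin evidence. The expected change is a 4.6-fold higher number from compound 2 to compound 3 (0.67 log units; beyond the scatter). The estimate for compound 3 is 25000 nM, with a range of 8000 nM to 80000 nM.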

Compound 3, half-maximal inhibitory concentration: > 100000 nM
Compound 3 was reported as a limit; the forecaster's own chance of this, stated with the estimate: 10%; at least 4.0-fold (0.60 log units) between middle value and limit.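

In this assay compound 3 gives > 100000 nM, a limit of the assay and not a number. On this aromatic carbon between two ring nitrogen atoms, the change to (pyrrolidin-2-yl)methoxy gives an at least 18-fold higher number from compound 2 to compound 3 (1.26 log units; beyond the scatter), so cyclopropylamino now stands ahead of both oxygen-linked groups shown, not just one. The other step, an at least 1.2-fold higher number from compound 1 to compound 3 (0.10 log units; that floor lies within the scatter), gives no order between those two oxygen-linked groups.

On these data alone, it remains open whether the nitrogen attachment or the three-membered ring matters more. Isopropylamino and cyclopropyloxy at this carbon would separate the two.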